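Ethyl to isopropyl on a weak series

The source may hold more compounds than are shown below. What is called first, only, known or untested is meant among the compounds shown, and "the series" means these compounds.

Among the measured compounds shown here, compound 2 `CCc1nc(C)c2cnn(CC)c(=O)n12` is the only member of the series with a numerical result: in a functional assay for inhibition, with Homo sapiens as the target (a higher number here means a weaker inhibitor, a lower number a stronger inhibitor), compound 2 gives 75600 nM, a weak inhibition. Compound 1 `C=CCn1ncc2c(C)nc(C(C)C)n2c1=O` returns no number in this assay, only a limit, at > 48000 nM. For compound 1 the record is the limit of > 48000 nM in this assay, at which 1 of the 2 values shown sits. For the measured compounds named here, compound 1 and compound 2 differ in more than one place, so the two results show only that one is a limit and the other a weak number, and no step between them is counted.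

Compound 3 `CCn1ncc2c(C)nc(C(C)C)n2c1=O` has not been measured. Against compound 2 the change is methyl in place of hydrogen on a saturated chain carbon bound to an aromatic carbon and a saturated chain carbon; cut one bond further out, the same difference reads ethyl to isopropyl. With one weak number and one limit as the whole record, no direction is expected beyond the scatter, and the step from compound 2 to compound 3 is estimated as a 1.3-fold lower number from compound 2 to compound 3 (0.10 log units; within the scatter) in this assay. Compound 3 is accordingly expected to give about 60000 nM in this assay, within a range of 20000 nM to 180000 nM, with a real chance that only a limit is reported.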

Compound 3, half-maximal inhibitory concentration: > 48000 nM
Compound 3: only a limit was reported; the forecaster's own chance of this, stated with the estimate: 50%; the middle value lies beyond the limit too.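

No step from compound 2 or compound 1 to compound 3 can be read, because compound 3 returns only a limit, as does compound 1: the limit of > 48000 nM in this assay, at which 2 of the 3 values shown sit.

The compounds shown leave open whether ethyl to isopropyl moves the result in this assay at all, and by how much.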